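The compounds below may be only part of what the source reports. "The series", "measured", "known", "first", "only" and "open" are said of these compounds alone.

Compound 2 `COc1ccc(N2CCN(Cn3nc(C(C)c4ccc(CC(C)C)cc4)oc3=S)CC2)cc1` stands lowest of the three compounds measured in a functional assay on the whole organism (strain Wister albino) for inhibition, with Rattus norvegicus as the target, read by paw edema, with stated times of 30 min and 3 h, at a dose of 10 mg/kg by the oral route; on this read-out lower numbers stand for less inhibition and higher numbers for more inhibition at the one dose given (going by the name of the read-out): compound 2 gives 42.6%, while compound 1 `CCOC(=O)C1CCN(Cn2nc(Cc3ccc(SC)cc3)oc2=S)CC1` gives 57.4% and compound 3 `CC(C)Cc1ccc(C(C)c2nn(CN3CCN(c4cccc(Cl)c4)CC3)c(=S)o2)cc1` gives 64.3%. Compound 4 `CC(C)Cc1ccc(C(C)c2nn(CN3CCN(c4ccc([N+](=O)[O-])cc4)CC3)c(=S)o2)cc1` differs from compound 2 by nitro in place of methoxy on an aromatic carbon. Among the measured compounds shown here, the one measured step that bears on this exchange is a number 21.7 percentage points higher from compound 2 to compound 3 (beyond the scatter), a different aryl group on the same amine nitrogen in a ring. A nitro group is not a chloro group, and it sits para to the large group, so that step is read only as a pointer toward a modest gain. Compound 4 is therefore expected to show a number 10.4 percentage points higher from compound 2 to compound 4 (beyond the scatter). For compound 4 the estimate in this assay is 53%, with a range from 40% to 66%.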

Compound 4, a percentage reported as inhibition, in the whole organism at one dose (the size of the read-out at that dose, not a potency): 75.1%
Beside the measured number, compound 4's estimate is 22.1 percentage points below it, and the stated range ends below it.
By their numbers in this assay, from the lowest: compound 2; then compounds 1 and 3 (each within the scatter of the next); then compound 4.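

In this assay the change from 4-methoxyphenyl to 4-nitrophenyl gives a number 32.5 percentage points higher from compound 2 to compound 4 (beyond the scatter) and so shows that the group at this place, para to a large group, can move the read-out a long way. The 4-nitrophenyl also improves on the 3-chlorophenyl, with a number 10.8 percentage points higher from compound 3 to compound 4 (beyond the scatter) in the same read-out, so the earlier aryl exchange had not reached the highest number in this set. No evidence bearing on the reason for either step is available. On these data alone, what an amine or a carboxylic acid would give in place of the nitro remains open, as does whether a nitrile there would match it.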